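Macrocycle series notes: substituent swap on a ring carbon

The source may report more compounds than this note shows. Statements on the series, on what has been measured and on what is new or still open speak of the compounds shown alone.

Measured so far in a functional assay on MCF7 cells (Homo sapiens) for antiproliferative activity, read by MTT assay, with a stated time of 48 h; a lower number here means a stronger inhibitor, a higher number a weaker inhibitor:
compound 1 `COC/C1=C/C[C@](C)(CCC=C(C)C)/C=C/[C@@H](OC(=O)C=C(C)C)[C@](C)(OC)/C=C/C1=O`: 16500 nM
compound 2 `CC(C)=CCC[C@]1(C)/C=C/[C@@H](OC(=O)C=C(C)C)[C@](C)(O)/C=C/C(=O)/C(CN(C)C)=C\C1`: 690 nM
compound 3 `CC(C)=CCC[C@]1(C)/C=C/[C@@H](OC(=O)C=C(C)C)[C@](C)(O)/C=C/C(O)/C(C=O)=C\C1`: 2320 nM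

Compound 2 gives the lowest number of the three. Compound 3 stands nearest to it, yet beyond the usual scatter, and compound 1 stands furthest, well beyond it. No pair here differs in a single place, so the three values show only their order, not a cause.

Compound 4 `CC(C)=CCC[C@]1(C)/C=C/[C@@H](OC(=O)C=C(C)C)[C@](C)(O)/C=C/C(=O)/C(C(=O)N2CCCC2)=C\C1` is not yet measured. It differs from compound 2 in one place: (pyrrolidin-1-yl)carbonyl in place of (dimethylamino)methyl on a double-bonded ring carbon.

For the measured compounds named here, no measured step of this kind exists, so the size is a guess. The change from compound 2 to compound 4 is expected to weaken inhibition, with an estimated step of a 2.2-fold higher number from compound 2 to compound 4 (0.34 log units; beyond the scatter). Compound 4 is thus estimated at 1500 nM in this assay, within a range of 400 nM to 6000 nM.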

Compound 4, half-maximal inhibitory concentration: 17200 nM
Compound 4: middle estimate off by 11-fold (1.06 log units), on the low side, and the stated range ends below it.
By their numbers in this assay, from the lowest: compound 2; then compound 3; then compounds 1 and 4 (each within the scatter of the next).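

For the compounds shown here, this double-bonded ring carbon proves sensitive to the substituent: in this assay, (pyrrolidin-1-yl)carbonyl in place of (dimethylamino)methyl gives a 25-fold higher number from compound 2 to compound 4 (1.40 log units; beyond the scatter), the first single-place step. The step is large even though both groups carry no net charge and have the same hydrogen-bond donor and acceptor counts. No measurement on hand explains it.

On these data alone, the swap introduces the five-membered ring and the carbonyl together, so which of them goes with the step remains open. A (pyrrolidin-1-yl)methyl or a (dimethylamino)carbonyl group on this carbon would separate the two.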